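The compounds below may be only part of what the source reports. "The series", "measured", "known", "first", "only" and "open" are said of these compounds alone.

Measured so far in a functional assay on DU-145 cells (Homo sapiens) for inhibition, read by trypan blue exclusion, with a stated time of 96 h; a higher number here means a weaker inhibitor of growth, a lower number a stronger inhibitor of growth:
- compound 1 `CC(=O)c1ccc(/C=C(/Sc2ccc(C)cc2)C(=O)c2ccc(Br)cc2)cc1` gives 50000 nM
- compound 2 `COc1ccc(OC)c(/C=C(/SCc2ccc(Cl)c(Cl)c2)C(=O)c2ccc(Cl)cc2)c1` gives 10000 nM
- compound 3 `Cc1ccc(S/C(=C/c2ccc(-c3ccccc3)cc2)C(=O)c2ccc(Br)cc2)cc1` gives 50000 nM

Compound 1 sits level with compound 3, and together they carry the highest numbers of the three, meaning the weakest growth inhibition; compound 2 stands furthest away, with the lowest number of the set. The unmeasured compound 4 `Cc1ccc(S/C(=C/c2ccc(F)c(C)c2)C(=O)c2ccc(Br)cc2)cc1` differs from compound 1 in one place: 4-fluoro-3-methylphenyl in place of 4-acetylphenyl on a double-bonded chain carbon bound to a double-bonded chain carbon. Going by the values given here, the only measured step that touches the same part of the structure is no change at the digits printed from compound 1 to compound 3 (within the scatter), where swapping the acetyl for a phenyl on that aromatic ring left the number where it was. Among the compounds with values here, the change to compound 4 is a different substitution on the same ring, so the one comparison available points to little movement. Compound 4 is therefore expected to stay close to compound 1, with an estimated step of a 1.3-fold lower number from compound 1 to compound 4 (0.10 log units; within the scatter). For compound 4 the estimate in this assay is 40000 nM, within a range from 15000 nM to 100000 nM.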

Compound 4, concentration for 50% growth inhibition: 25000 nM
For compound 4 the middle estimate is 1.6-fold (0.20 log units) above the measured one, within the range that was stated.
By their numbers in this assay, from the lowest: compound 2; then compounds 4, 1 and 3 (each within the scatter of the next).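

In this assay, putting 4-fluoro-3-methylphenyl in place of 4-acetylphenyl gives a 2.0-fold lower number from compound 1 to compound 4 (0.30 log units; within the scatter), so this swap has no clear effect on the number. The earlier step, no change at the digits printed from compound 1 to compound 3 (within the scatter), covered only a phenyl in place of the acetyl, while this one replaces the whole 4-acetylphenyl group with a differently substituted ring. With two different changes at this place, both within the scatter, this part of compound 1 tolerates more than one replacement without a clear shift in growth inhibition, and no measurement at hand explains this.

From the compounds shown here alone, it remains open whether an amine or a carboxylic acid on this ring would move the number beyond the scatter. Going by these compounds, it is also open whether the same tolerance holds with the other parts of the core changed.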